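The source may hold more compounds than are shown below. What is called first, only, known or untested is meant among the compounds shown, and "the series" means these compounds.

Compound 1 `C(=C/c1c[nH]c2ccccc12)\c1ccncc1` was measured in an assay for inhibition of Tryptophan 2,3-dioxygenase (Rattus norvegicus) (on this read-out higher numbers stand for weaker inhibition and lower numbers for stronger inhibition), where compound 1 gives 30 nM. Within the data shown here, only one other compound has been measured with it: compound 2 `Fc1ccc2[nH]cc(/C=C/c3ccncc3)c2c1`, which in this assay gives 40 nM. The step of a 1.3-fold higher number from compound 1 to compound 2 (0.12 log units; within the scatter) is the whole of what is known, so compound 1 sits together with compound 2 within the usual scatter, and neither number can be set apart from the other.

Compound 3 `Fc1ccc2c(/C=C/c3ccncc3)c[nH]c2c1` differs from compound 1 by fluoro in place of hydrogen on an aromatic carbon. Among the measured compounds shown here, the one measured step that bears on it, the fluoro entering in the move from compound 1 to compound 2, was a 1.3-fold higher number from compound 1 to compound 2 (0.12 log units; within the scatter) and stayed within the scatter. On that basis a step of no more than the scatter, in either direction, is expected for compound 3, namely a 1.3-fold higher number from compound 1 to compound 3 (0.12 log units; within the scatter). The estimate for compound 3 in this assay is therefore 40 nM, with a range from 15 nM to 120 nM.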

Compound 3, inhibition constant: 30 nM
The estimate for compound 3 lay 1.3-fold (0.12 log units) above the measured number; the range from low to high includes it.
By their numbers in this assay, from the lowest: compounds 1, 3 and 2 (each within the scatter of the next).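

Among these compounds, the step of no change at the digits printed from compound 1 to compound 3 (within the scatter) shows that fluoro in place of hydrogen is accepted at a second aromatic carbon of the core of compound 1, not only at the one changed in compound 2. In this assay the two fluoro compounds and compound 1 therefore all stay within the scatter of one another, so this position, on the six-membered aromatic ring of carbon only, can carry the fluoro with no readable change. Nothing available here explains why the read-out holds at either place.

The compounds shown leave open whether chloro, methoxy, an amine or a carboxylic acid at this position would hold the number as fluoro does. They also leave open whether a fluoro on the remaining aromatic carbons of this ring would behave in the same way.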